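Azetidine to Morpholine Amide in a Dipeptidyl Peptidase Series

This account rests on a few compounds, and the source may have more. Where it says the series, first, only, none or still open, it means among the compounds named here.

Compound 2 `C[C@@H]1N[C@H](C(=O)N2CCC[C@H]2C#N)C[C@@H]1C(=O)N1CCC1`: 88%
Compound 1 `N#C[C@@H]1CCCN1C(=O)[C@@H]1C[C@H](C(=O)N2CCCCCCC2)CN1`: "not determined" (no result reported)
Compound 3 `CCN(CC)C(=O)[C@@H]1CN[C@H](C(=O)N2CCC[C@H]2C#N)C1`: "not determined" (no result reported)

Among the compounds with values here, compound 2 is the only member of this set with a number in an assay on the whole organism (plasma, strain Sprague-Dawley) for inhibition of Dipeptidyl peptidase 4 (Rattus norvegicus), with a stated time of 10 h, at a dose of 1 mg/kg by the oral route; on this read-out lower numbers stand for less inhibition and higher numbers for more inhibition at the one dose given (going by the name of the read-out); compound 1 is reported as "not determined" (no result reported) and compound 3 as "not determined" (no result reported) there, so compound 2 stands alone as the reference. Compound 4 `C[C@@H]1N[C@H](C(=O)N2CCC[C@H]2C#N)C[C@@H]1C(=O)N1CCOCC1` differs from it by one change, (morpholin-4-yl in place of azetidin-1-yl on a carbonyl carbon). Within the data shown here, no measured pair in this set shows what such a change does, so the step is judged from compound 2 alone. Because compound 2 gives 88%, little room remains upward, and the expected step of a number 8 percentage points lower from compound 2 to compound 4 (within the scatter) is small and downward, within or just beyond the scatter. Compound 4 is estimated at 80%, between 60% and 92%.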

Compound 4, a percentage reported as inhibition, in the whole organism at one dose (the size of the read-out at that dose, not a potency): 85%
Beside the measured number, compound 4's estimate is 5 percentage points below it, and the stated range covers the measured number.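

In this assay, the step of a number 3 percentage points lower from compound 2 to compound 4 (within the scatter) comes with morpholin-4-yl in place of azetidin-1-yl on a carbonyl carbon. Within the data shown here, this is the first measured pair at this place, and it shows that the four-membered and six-membered rings read alike at this one dose, even though only the morpholin-4-yl group carries a hydrogen-bond acceptor. No evidence on the cause is available here. The pair leaves open how an open-chain amine such as dimethylamino or a carboxylic acid at this carbonyl carbon would read. It also leaves open whether the two compounds would still read alike at a lower dose.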